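Acyl group in place of propargyl on the chalcone oxygen

This account rests on a few compounds, and the source may have more. Where it says the series, first, only, none or still open, it means among the compounds named here.

Compound 2 `C#CCOc1cc(/C=C/C(=O)c2ccc(OC)c3c2OC(C)(C)C=C3)ccc1OC` carries a propargyl group on a ring oxygen of the shared core. In a functional assay on A-375 cells (Homo sapiens) for cytotoxicity, read by MTT assay (on this read-out higher numbers stand for weaker inhibition and lower numbers for stronger inhibition), compound 2 sits at the assay limit, > 10000 nM, with no number read. Compound 1 `COc1ccc(/C=C/C(=O)c2ccc(OC)c3c2OC(C)(C)C=C3)cc1OCC=C(C)C` also sits at the limit, > 10000 nM. Compound 3 `CCC(=O)Oc1cc(/C=C/C(=O)c2ccc(OC)c3c2OC(C)(C)C=C3)ccc1OC` gives 240 nM in this assay. The step that the two limits leave unreadable from compound 1 to compound 2 cannot be read. The step of an at least 41-fold lower number from compound 2 to compound 3 (1.61 log units; beyond the scatter) is large, as is an at least 41-fold lower number from compound 1 to compound 3 (1.61 log units; beyond the scatter); both start from the limit of > 10000 nM in this assay, at which 2 of the 3 values shown sit.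

Compound 4 `COc1cccc(C(=O)Oc2cc(/C=C/C(=O)c3ccc(OC)c4c3OC(C)(C)C=C4)ccc2OC)c1` differs from compound 2 by (3-methoxyphenyl)carbonyl in place of propargyl on an oxygen on an aromatic ring. Like the propanoyl of compound 3, the entering (3-methoxyphenyl)carbonyl is an acyl group on that same oxygen, so the step from compound 2 to compound 3 is the one that bears on this change, and a drop of similar size is expected, an at least 28-fold lower number from compound 2 to compound 4 (1.45 log units; beyond the scatter). Compound 4 is therefore expected to give about 350 nM in this assay, between 80 nM and 3000 nM.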

Compound 4, half-maximal inhibitory concentration: 800 nM
Beside the measured number, compound 4's estimate is 2.3-fold (0.36 log units) below it; the measured number falls inside the stated range.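

In this assay, a second acyl group on this oxygen also gives a readable value: an at least 12-fold lower number from compound 2 to compound 4 (1.09 log units; beyond the scatter) and an at least 12-fold lower number from compound 1 to compound 4 (1.09 log units; beyond the scatter), so among the compounds shown the gain is not confined to propanoyl. The acyl group is not interchangeable, however: a 3.3-fold higher number from compound 3 to compound 4 (0.52 log units; beyond the scatter), a modest step with 3-methoxyphenyl in place of ethyl on the carbonyl carbon, so what sits on that carbon also moves the number. The two large steps start from assay limits and fix only a minimum size: the limit of > 10000 nM in this assay, at which 2 of the 4 values shown sit.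

As far as these compounds go, with only ethyl and 3-methoxyphenyl on the carbonyl carbon, it stays open whether a butanoyl or an unsubstituted benzoyl would fall nearer compound 3 or compound 4. From the compounds shown here alone, whether the ester link itself is needed also stays open, and a carbamate on the same oxygen would address this.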